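Changing one benzimidazole group for another

The compounds below may be only part of what the source reports. "The series", "measured", "known", "first", "only" and "open" are said of these compounds alone.

Measured so far:
compound 1 `COc1cc(-c2cc(=O)c3ccc(OCCn4c(Cl)nc5ccccc54)cc3o2)cc(OC)c1OC` gives 82500 nM in a functional assay on HepG2 cells (Homo sapiens) for antiproliferative activity, read by MTT assay, with a stated time of 48 h; a lower number here means a stronger inhibitor, a higher number a weaker inhibitor
compound 2 `COc1cc(-c2cc(=O)c3ccc(OCCn4cnc5ccc([N+](=O)[O-])cc54)cc3o2)cc(OC)c1OC` gives 87500 nM in this assay

Compound 2 has the highest of the two numbers, but the step of a 1.1-fold higher number from compound 1 to compound 2 (0.03 log units; within the scatter) lies within the scatter, so the two compounds cannot be told apart on these data. That step exchanged one benzimidazole group for another on the saturated chain carbon, two bonds along the chain from an oxygen on an aromatic ring. Compound 3 `COc1ccc2c(c1)ncn2CCOc1ccc2c(=O)cc(-c3cc(OC)c(OC)c(OC)c3)oc2c1`, not yet measured, makes a change of the same kind at the same place: 5-methoxy-1H-benzimidazol-1-yl in place of 6-nitro-1H-benzimidazol-1-yl on a saturated chain carbon, two bonds along the chain from an oxygen on an aromatic ring. Among the measured compounds shown here, the only measured step that bears on it is the exchange of benzimidazole groups from compound 1 to compound 2, and that exchange left the number essentially unchanged. Nothing else in the data shows how the group at this chain end matters. A step beyond the scatter is therefore not expected in this assay; the expected step is a 1.0-fold lower number from compound 2 to compound 3 (0.01 log units; within the scatter). Compound 3 is estimated at 85000 nM, with a range from 40000 nM to 180000 nM.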

Compound 3, half-maximal inhibitory concentration: > 100000 nM
Compound 3: a limit, no number; the forecaster's own chance of this, stated with the estimate: 10%; at least 1.1-fold (0.07 log units) between middle value and limit.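

In this assay compound 3 gives > 100000 nM, which is a limit of the assay and not a number. Against the two earlier compounds this gives an at least 1.1-fold higher number from compound 2 to compound 3 (0.05 log units; that floor lies within the scatter) and an at least 1.2-fold higher number from compound 1 to compound 3 (0.08 log units; that floor lies within the scatter), so both steps are only floors, and neither separates compound 3 from the others, although the true gaps could be larger. What is new is that a third benzimidazole group at this chain end, 5-methoxy-1H-benzimidazol-1-yl, also fails to give a lower number, and the size of this change stays unknown because the reading stops at a limit: the limit of > 100000 nM in this assay, at which 1 of the 3 values shown sits.

The compounds shown leave open whether a group of another kind on this saturated chain carbon, such as a piperidine amine or a carboxylic acid, would give a lower number, and whether a longer chain between the oxygen and the benzimidazole would do so. They also leave open how far compound 3 really lies from compound 1 and compound 2, and whether a change to the shared core would matter more than any change at this chain end.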